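The source may hold more compounds than are shown below. What is called first, only, known or untested is meant among the compounds shown, and "the series" means these compounds.

In a functional assay on A549 cells (Homo sapiens) for inhibition, read by CCK-8 assay, with a stated time of 48 h (a higher number here means a weaker inhibitor, a lower number a stronger inhibitor), compound 1 `COc1cc(-c2cc3nccc(-c4cc(OC)c(OC)c(OC)c4)n3n2)cc(OC)c1OC` gives > 10000 nM and this is a limit of the assay, not a number. Compound 2 `COc1cc(-c2cc3nccc(-c4c[nH]c5ccccc45)n3n2)cc(OC)c1OC` gives > 10000 nM and this too is only a limit. Among the measured compounds shown here, compound 3 `COc1cc(-c2ccnc3cc(-c4ccc(C)cc4)nn23)cc(OC)c1OC` reads 3 nM and so supplies the only actual number in the set, which makes it the sole firm reference point for what follows.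

Compound 4 `COc1cc(-c2ccnc3cc(-c4ccc5cc[nH]c5c4)nn23)cc(OC)c1OC` keeps the rest of compound 3 but carries 1H-indol-6-yl in place of 4-methylphenyl on an aromatic carbon of a five-membered aromatic ring with 2 nitrogen, part of a fused or bridged system of two rings (1H-indol-6-yl in place of 4-methylphenyl on an aromatic carbon). This exchange brings in a second ring and a hydrogen-bond donor.

For the measured compounds named here, no pair measured so far differs in one place only, so the size of the step has to be judged without a direct precedent. Compound 3 at 3 nM already sits very low, so a weaker reading is the likelier direction. A moderate weakening beyond the usual scatter is expected, and the estimated change is a 6.7-fold higher number from compound 3 to compound 4 (0.82 log units; beyond the scatter) in this assay, well short of the limit.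

For compound 4 the estimated half-maximal inhibitory concentration is 20 nM, with an expected range from 3 nM to 300 nM.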

Compound 4, half-maximal inhibitory concentration: 170 nM
Compound 4: middle estimate off by 8.5-fold (0.93 log units), on the low side; low and high end bracket the measured number.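

In this assay, among the compounds shown here, the exchange of 4-methylphenyl for 1H-indol-6-yl gives the only step that can be read so far, a 57-fold higher number from compound 3 to compound 4 (1.75 log units; beyond the scatter), and it is large. It shows that this aromatic carbon, next to the ring nitrogen, is not indifferent to the group it carries: with everything else held as in compound 3, a group that enters with a second ring and a hydrogen-bond donor loses much of the strength seen with 4-methylphenyl. Even so, compound 4 still gives an actual number rather than a limit, so this change weakens the compound without taking it to the end of the measurable range: the limit of > 10000 nM in this assay, at which 2 of the 4 values shown sit.

For the compounds shown here, the single step changes ring count and hydrogen-bond donor count together, so it cannot separate the second ring from the donor, and a naphthalen-2-yl or a 1-methyl-1H-indol-6-yl group in the same place would be needed to tell them apart. From the compounds shown here alone, how a smaller group, such as a plain phenyl, or a 4-aminophenyl group with its amine would read at this position also remains open.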